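The source may report more compounds than this note shows. Statements on the series, on what has been measured and on what is new or still open speak of the compounds shown alone.

Compound 1 `Oc1ccc(-c2cc(-c3ccccc3O)cc(-c3cccc(O)c3)n2)cc1` is the most potent of the three measured compounds in a functional assay on T47D cells (Homo sapiens) for cytotoxicity, read by CCK-8 assay, with a stated time of 4 days (on this read-out lower numbers stand for stronger inhibition and higher numbers for weaker inhibition), giving 650 nM. Compound 2 `Oc1cccc(-c2cc(-c3ccccc3O)cc(-c3cccc(O)c3)n2)c1` gives 4570 nM in this assay, and compound 3 `Oc1ccc(-c2cc(-c3cccc(O)c3)cc(-c3cccc(O)c3)n2)cc1` gives 3920 nM. Both steps away from compound 1 weaken the read-out beyond the scatter: a 7.0-fold higher number from compound 1 to compound 2 (0.85 log units; beyond the scatter), and a 6.0-fold higher number from compound 1 to compound 3 (0.78 log units; beyond the scatter). In each case a 3-hydroxyphenyl group was brought in at the expense of another hydroxyphenyl isomer, and each time the number rose.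

Compound 4 `Oc1ccc(-c2cc(-c3ccccc3O)cc(-c3ccccc3O)n2)cc1` is built from the same atoms as compound 1, joined differently: 2-hydroxyphenyl in place of 3-hydroxyphenyl on an aromatic carbon. Going by the values given here, this change runs opposite to the one from compound 1 to compound 3, where a 2-hydroxyphenyl gave way to a 3-hydroxyphenyl and the number rose, and it also removes the 3-hydroxyphenyl that compound 2 shows to be unfavourable when it replaces the 4-hydroxyphenyl. Both measured steps therefore point toward a lower number for compound 4 in this assay, though neither is the same swap at the same site, so the expectation carries real uncertainty. Compound 4 is thus expected to give 250 nM, within a range of 80 nM to 800 nM, a step estimated as a 2.6-fold lower number from compound 1 to compound 4 (0.41 log units; beyond the scatter).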

Compound 4, half-maximal inhibitory concentration: 960 nM
Compound 4: the middle estimate sits 3.8-fold (0.58 log units) below what was measured; measured number above the stated range.
By their numbers in this assay, from the lowest: compounds 1 and 4 (each within the scatter of the next); then compounds 3 and 2 (each within the scatter of the next).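

At the aromatic carbon next to the ring nitrogen, the change to 2-hydroxyphenyl in place of 3-hydroxyphenyl gives in this assay a 1.5-fold higher number from compound 1 to compound 4 (0.17 log units; within the scatter), so at this position these two hydroxyphenyl isomers cannot be told apart by this read-out. The earlier steps shown here changed the other two hydroxyphenyl groups of compound 1 and gave a 7.0-fold higher number from compound 1 to compound 2 (0.85 log units; beyond the scatter) and a 6.0-fold higher number from compound 1 to compound 3 (0.78 log units; beyond the scatter), so the sensitivity to hydroxyphenyl isomers seen there does not extend to this position, and compound 4 is the exception among the three steps taken from compound 1. Nothing given here accounts for the different behaviour of this position.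

The compounds shown leave open whether this position also accepts a 4-hydroxyphenyl, and whether the hydroxyl matters at all here, which an unsubstituted phenyl, a methoxyphenyl or an aminophenyl at the same carbon would address. They also leave open whether the 3-hydroxyphenyl and 2-hydroxyphenyl would remain interchangeable at this position if the 4-hydroxyphenyl or the 2-hydroxyphenyl elsewhere on the core were replaced.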